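The compounds below may be only part of what the source reports. "The series", "measured", "known", "first", "only" and "open" are said of these compounds alone.

Of the compounds shown here, three built on one shared core have been measured in a functional assay on HepG2 cells (Homo sapiens) for antiproliferative activity, read by MTT assay, with a stated time of 48 h; on this read-out lower numbers stand for stronger inhibition and higher numbers for weaker inhibition. Compound 1 `CCCC(C)Oc1ccc(C(=O)/C=C/c2c(/C=C/c3ccc(OC)cc3)cc(OC)cc2OC)cc1` gives 11.1 ug/mL, compound 2 `COc1ccc(/C=C/c2cc(OC)cc(OC)c2/C=C/C(=O)c2ccc(F)cc2)cc1` gives 12.2 ug/mL, and compound 3 `CCOc1ccc(C(=O)/C=C/c2c(/C=C/c3ccc(OC)cc3)cc(OC)cc2OC)cc1` gives 8 ug/mL. Compound 3 thus lies within the scatter of both others, so these numbers do not rank the three.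

Compound 4 `COc1ccc(/C=C/c2cc(OC)cc(OC)c2/C=C/C(=O)c2ccccc2)cc1` is compound 3 with a single change: hydrogen in place of ethoxy on an aromatic carbon, para to a large group (hydrogen in place of ethoxy on an aromatic carbon). Within the data shown here, no measured compound has hydrogen at that place, so the closest guide comes from the steps that exchange the group there. Going from 1-methylbutoxy to ethoxy gives a 1.4-fold lower number from compound 1 to compound 3 (0.14 log units; within the scatter). Going from fluoro to ethoxy gives a 1.5-fold lower number from compound 2 to compound 3 (0.18 log units; within the scatter). Going from 1-methylbutoxy to fluoro gives a 1.1-fold higher number from compound 1 to compound 2 (0.04 log units; within the scatter). All three stay within the scatter, although the groups exchanged are quite unlike one another. Removing the group entirely is still a different kind of change, which leaves real uncertainty.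

In this assay, no step beyond the scatter is therefore expected, and the estimated step is a 1.3-fold higher number from compound 3 to compound 4 (0.10 log units; within the scatter). The estimate for compound 4 is 10 ug/mL, with an expected range from 5.5 ug/mL to 18 ug/mL.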

Compound 4, half-maximal inhibitory concentration: 6.8 ug/mL
Compound 4: the middle estimate sits 1.5-fold (0.17 log units) above what was measured, within the range that was stated.
By their numbers in this assay, from the lowest: compounds 4, 3, 1 and 2 (each within the scatter of the next).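

In this assay, removing the ethoxy group altogether and leaving only a hydrogen on the aromatic carbon, para to a large group, gives a 1.2-fold lower number from compound 3 to compound 4 (0.07 log units; within the scatter) and so adds the unsubstituted ring as a baseline for this position. Hydrogen compared with the other two groups at the same place gives a 1.8-fold lower number from compound 2 to compound 4 (0.25 log units; within the scatter) for fluoro and a 1.6-fold lower number from compound 1 to compound 4 (0.21 log units; within the scatter) for 1-methylbutoxy, so across these four compounds, even complete loss of the group does not move the number beyond the usual scatter of the assay. Nothing in the available data explains why these exchanges make so little difference.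

The compounds shown leave open whether this place would stay as insensitive with a group of another kind on the same aromatic carbon, such as an amine or a carboxylic acid. They also leave open whether hydrogen and ethoxy would still sit this close together if one of the methoxy groups elsewhere on the shared core were exchanged for a different group.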